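Mirror-image partner of compound 2: expected read-out

The source may report more compounds than this note shows. Statements on the series, on what has been measured and on what is new or still open speak of the compounds shown alone.

Two measured members of the series set the frame. Compound 1 `Cc1ccccc1NC(=O)N[C@@H](C)c1ccccc1` gives 100% in an ADME assay on the whole organism with Oryza sativa as the target, tested at 0.1 uM; a lower number here means a stronger effect, a higher number a weaker effect of the compound at the concentration tested. Compound 2 `C[C@@H](NC(=O)Nc1ccccc1C(F)(F)F)c1ccccc1` gives 99% in this assay; this number and that of compound 1 lie within the scatter of each other, so neither compound can be placed above the other on this read-out, and both sit close to the top of the scale. Compound 3 `C[C@H](NC(=O)Nc1ccccc1C(F)(F)F)c1ccccc1` has not yet been measured in this assay. Compared with compound 2, (the two compounds have the same atoms and bonds and differ only in configuration as drawn: 1 of 1 stereo elements differ; a stereocentre at a saturated chain carbon is drawn R in compound 2 and S in compound 3). Going by the values given here, no step between two measured compounds is available, so the size of this change cannot be read from the series itself; given that compound 2 and compound 1 both stand near the top of the scale, a step of no more than the scatter is expected in this assay, with any movement towards a lower number. For compound 3 the expected read-out is estimated at 97%, with an expected range from 85% to 100%. The expected step is a number 2 percentage points lower from compound 2 to compound 3 (within the scatter).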

Compound 3, a percentage reported as activity, at one concentration (the size of the read-out at that concentration, not a potency): 97%
The estimate for compound 3 equals the measured number at the digits printed; measured number inside the range.
By their numbers in this assay, from the lowest: compounds 3, 2 and 1 (each within the scatter of the next).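

In this assay, inverting the stereocentre at the saturated chain carbon gives a number 2 percentage points lower from compound 2 to compound 3 (within the scatter), so R and S cannot be told apart on this read-out at this concentration. This step can be tied to that stereocentre alone because of one fact: the fact that compounds 2 and 3 differ only in the configuration as drawn

Trifluoromethyl in place of methyl on an aromatic carbon, the other change now readable, gives a number 3 percentage points lower from compound 1 to compound 3 (within the scatter), so this exchange also produces no separation in this assay.

As far as these compounds go, with all steps inside the scatter, it remains open whether any change on this series can move the read-out clearly away from the top of the scale at this concentration. A carboxylic acid or an amine in place of trifluoromethyl on that aromatic carbon, or a longer chain at the stereocentre, would test this.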